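A few compounds are considered here, and "the series" means these few. Any claim that something is new, unique, unknown or untested is made for them only; others in the source may bear on it.

Measured so far:
compound 1 `Nc1nc(N/N=C/c2cccnc2Cl)nc2c1ncn2[C@@H]1O[C@H](CO)[C@@H](O)[C@H]1O`, an assay on CHO-K1 cells for displacement of a labelled ligand from adenosine receptor A1 (Homo sapiens), read by scintillation counting, with a stated time of 60 min (on this read-out lower numbers stand for stronger inhibition and higher numbers for weaker inhibition), 4.6 nM
compound 2 `Nc1nc(N/N=C/c2ccc(Br)cn2)nc2c1ncn2[C@@H]1O[C@H](CO)[C@@H](O)[C@H]1O`, 4.7 nM

Compound 2 has the highest of the two numbers shown, though compound 1 sits within the scatter of it, a 1.0-fold higher number from compound 1 to compound 2 (0.01 log units; within the scatter). Compound 3 `Nc1nc(N/N=C/C2CCCC2)nc2c1ncn2[C@@H]1O[C@H](CO)[C@@H](O)[C@H]1O` differs from compound 2 in one place: cyclopentyl in place of 5-bromopyridin-2-yl on a carbon with a double bond to nitrogen. Among the compounds with values here, the only measured step, from compound 1 to compound 2, swapped one aromatic ring for another and stayed within the scatter; it does not directly bear on replacing an aromatic ring with a saturated carbon ring. For compound 3 a somewhat higher number is expected, a 3.2-fold higher number from compound 2 to compound 3 (0.50 log units; beyond the scatter), with wide uncertainty. The estimate for compound 3 is 15 nM, between 3 nM and 80 nM.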

Compound 3, inhibition constant: 5.6 nM
Beside the measured number, compound 3's estimate is 2.7-fold (0.43 log units) above it; measured number inside the range.
By their numbers in this assay, from the lowest: compounds 1, 2 and 3 (each within the scatter of the next).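

In this assay, cyclopentyl in place of 5-bromopyridin-2-yl gives a 1.2-fold higher number from compound 2 to compound 3 (0.08 log units; within the scatter) and cyclopentyl in place of 2-chloropyridin-3-yl gives a 1.2-fold higher number from compound 1 to compound 3 (0.09 log units; within the scatter) on the same carbon with a double bond to nitrogen. The earlier step only swapped one aromatic ring for another, whereas these show that a non-aromatic ring of carbon only also reads level with both aromatic rings. No available evidence explains this result. The compounds shown leave open whether a group without a ring, such as a longer chain, or a ring carrying an amine or a carboxylic acid, would also read level.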